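Methyl for chloro at the ortho position of the benzylidene series

The compounds below may be only part of what the source reports. "The series", "measured", "known", "first", "only" and "open" are said of these compounds alone.

Compound 1 `COc1cccc(/C=C2\CCc3ccccc3C2=O)c1OC` gives 38200 nM in a functional assay on L1210 cells (Mus musculus) for inhibition; on this read-out lower numbers stand for stronger inhibition and higher numbers for weaker inhibition. Compound 2 `O=C1/C(=C/c2ccccc2Cl)Cc2ccccc21` gives 152000 nM in this assay, the highest of the two numbers available, with compound 1 as its nearest neighbour at a number that is lower beyond the scatter. Compound 3 `O=C1/C(=C/c2ccc(Cl)cc2Cl)Cc2ccccc21` gives > 500000 nM in this assay, which is a limit of the assay and not a number.

Within the data shown here, the one measured step that touches the chloro substituent is an at least 3.2-fold higher number from compound 2 to compound 3 (0.51 log units; beyond the scatter). It adds a second chloro; it says nothing about exchanging the first.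

Compound 4 `Cc1ccccc1/C=C1\Cc2ccccc2C1=O` is not yet measured in this assay. The change from compound 2 to compound 4 is methyl in place of chloro on an aromatic carbon. Among the measured compounds shown here, no measured pair separates methyl from chloro at this place, and the only chloro-related step, an at least 3.2-fold higher number from compound 2 to compound 3 (0.51 log units; beyond the scatter), concerns a further chloro rather than a swap. The expectation is therefore a step of a 1.0-fold lower number from compound 2 to compound 4 (0.01 log units; within the scatter), within the scatter, with no direction claimed beyond it.

Compound 4 is estimated at 150000 nM in this assay, with a range from 50000 nM to 450000 nM.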

Compound 4, half-maximal inhibitory concentration: 208000 nM
Estimate against measurement, compound 4: 1.4-fold (0.14 log units) below, and the stated range covers the measured number.
By their numbers in this assay, from the lowest: compound 1; then compounds 2 and 4 (each within the scatter of the next). At a limit, above all of these: compound 3.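

The exchange of chloro for methyl gives, in this assay, a 1.4-fold higher number from compound 2 to compound 4 (0.14 log units; within the scatter), so the two groups cannot be told apart at this place, on an aromatic carbon ortho to a large group. Among these compounds, until now the only measured step touching chloro was the addition of a further one, an at least 3.2-fold higher number from compound 2 to compound 3 (0.51 log units; beyond the scatter), and that step said nothing about whether the first chloro could be exchanged; compound 4 shows that it can be, with no change beyond the scatter. Nothing measured here gives a reason for either step, and the one available note on the assay limit does not bear on this exchange.

Going by these compounds, whether the same holds for groups less like these two at this place, such as an amine, a carboxylic acid or a longer chain, remains open. On these data alone, compound 1 differs from compound 2 and compound 4 in more than one place, so its number cannot be read as the effect of any single change, and what sets it apart also remains open.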